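From Methyl to Chloro on the Aryl Ring

This account rests on a few compounds, and the source may have more. Where it says the series, first, only, none or still open, it means among the compounds named here.

Compound 2 `Cc1ccc(NC(=O)NC(=O)c2ccc(OCc3ccc(F)cc3)cc2)cc1-c1nc2ccccc2[nH]1` is the more potent of the two measured compounds. In a functional assay on MNK45 cells (Homo sapiens) for inhibition, read by MTT assay, with a stated time of 48 h (on this read-out lower numbers stand for stronger inhibition and higher numbers for weaker inhibition), compound 2 gives 240 nM, the lowest of the two numbers, while compound 1 `Cc1ccc(NC(=O)NC(=O)c2ccc(OCc3cccc(Cl)c3)cc2)cc1-c1nc2ccccc2[nH]1` gives 28000 nM. Within the data shown here, the single measured step, a 120-fold lower number from compound 1 to compound 2 (2.07 log units; beyond the scatter), concerns the benzyl ether end of the molecule and leaves untouched the ring that changes next. Compound 3 `O=C(NC(=O)c1ccc(OCc2ccc(F)cc2)cc1)Nc1ccc(Cl)c(-c2nc3ccccc3[nH]2)c1` keeps everything of compound 2 except for one group: chloro in place of methyl on an aromatic carbon. Among the measured compounds shown here, no measured step bears on this exchange, since both measured compounds carry the methyl there, so neither the direction nor the size of the change can be read from the data. The step of a 1.3-fold higher number from compound 2 to compound 3 (0.10 log units; within the scatter) is therefore expected to stay within the usual scatter. Compound 3 is estimated at 300 nM, with a range from 70 nM to 1500 nM that is kept wide to allow for the absence of any matching precedent in this assay.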

Compound 3, half-maximal inhibitory concentration: 350 nM
Estimate against measurement, compound 3: 1.2-fold (0.07 log units) below; measured number inside the range.
By their numbers in this assay, from the lowest: compounds 2 and 3 (each within the scatter of the next); then compound 1.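

In this assay, among these compounds, the exchange of methyl for chloro on this aromatic carbon, ortho to a 1H-benzimidazol-2-yl group, gives a first reading for this position (a 1.5-fold higher number from compound 2 to compound 3 (0.16 log units; within the scatter)), so compound 2 and compound 3 cannot be told apart on this read-out. Compound 1 and compound 2 both carry the methyl and could say nothing about this place, whereas the new pair shows that, for these two groups and with the 4-fluorophenyl end in place, the choice between methyl and chloro leaves the number within the scatter, in contrast to the exchange at the benzyl ether end (a 120-fold lower number from compound 1 to compound 2 (2.07 log units; beyond the scatter)). No measurement shown here accounts for the close match between the two groups.

Open, as far as these compounds go, is whether other groups on the same aromatic carbon, such as methoxy, an amine, a carboxylic acid or trifluoromethyl, would match methyl and chloro in the same way or shift the number beyond the scatter. Also open, from the compounds shown here alone, is whether chloro and methyl would still match when the 3-chlorophenyl group of compound 1 stands at the far end of the molecule.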